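Swapping 8-hydroxyquinolin-2-yl for 1H-indol-6-yl on a shared core

A few compounds are considered here, and "the series" means these few. Any claim that something is new, unique, unknown or untested is made for them only; others in the source may bear on it.

- compound 1 `Cn1c(=O)c(S(=O)(=O)c2ccc(F)cc2F)cc2cnc(Nc3ccc4sccc4c3)nc21`: 500 nM
- compound 2 `Cn1c(=O)c(S(=O)(=O)c2ccc(F)cc2F)cc2cnc(Nc3ccc4[nH]ncc4c3)nc21`: 50000 nM
- compound 3 `Cn1c(=O)c(S(=O)(=O)c2ccc(F)cc2F)cc2cnc(Nc3ccc4cccc(O)c4n3)nc21`: 5000 nM

All three values come from a functional assay on K562 cells (Homo sapiens) for inhibition, read by trypan blue exclusion, with a stated time of 72 h (on this read-out lower numbers stand for stronger inhibition and higher numbers for weaker inhibition), and the three compounds share one core. Compound 3 at 5000 nM is the middle of the three numbers. Its neighbours lie equally far away on either side: a 10-fold higher number from compound 1 to compound 3 (1.00 log units; beyond the scatter) and a 10-fold lower number from compound 2 to compound 3 (1.00 log units; beyond the scatter) are both beyond the scatter.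

Compound 4 `Cn1c(=O)c(S(=O)(=O)c2ccc(F)cc2F)cc2cnc(Nc3ccc4cc[nH]c4c3)nc21` has not yet been measured. It carries 1H-indol-6-yl in place of 8-hydroxyquinolin-2-yl on a nitrogen on an aromatic ring, and the counted change is 1H-indol-6-yl in place of 8-hydroxyquinolin-2-yl on a nitrogen on an aromatic ring in all.

Every measured step changes this same place. The largest, a 100-fold higher number from compound 1 to compound 2 (2.00 log units; beyond the scatter) and beyond the scatter, shows how much the group here can shift the number in these compounds. Among the compounds with values here, no measured compound carries 1H-indol-6-yl, so nothing fixes the direction. Its nearest relatives by name, 1-benzothiophen-5-yl in compound 1 and 1H-indazol-5-yl in compound 2, sit at opposite ends of the range. The middle of that range is therefore the expected place for compound 4, and the uncertainty is wide.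

The estimated step is a 1.7-fold lower number from compound 3 to compound 4 (0.22 log units; within the scatter) and no larger change is expected.

For compound 4 the estimate is 3000 nM with an expected range from 400 nM to 30000 nM in this assay.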

Compound 4, half-maximal inhibitory concentration: 5000 nM
Estimate against measurement, compound 4: 1.7-fold (0.22 log units) below; the range from low to high includes it.
By their numbers in this assay, from the lowest: compound 1; then compounds 3 and 4 (each within the scatter of the next); then compound 2.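

In this assay, 1H-indol-6-yl brings a five-membered aromatic ring where 8-hydroxyquinolin-2-yl has a six-membered aromatic ring with one hetero atom, and it also lacks the hydroxy group, yet the two compounds cannot be told apart (no change at the digits printed from compound 3 to compound 4 (within the scatter)). So at this position, this particular swap of ring and hydroxy group leaves the number where it was, while the other swaps do not: the 1H-indazol-5-yl comparison gives a 10-fold lower number from compound 2 to compound 4 (1.00 log units; beyond the scatter), and the 1-benzothiophen-5-yl comparison gives a 10-fold higher number from compound 1 to compound 4 (1.00 log units; beyond the scatter). Each of these two swaps alters both the ring atoms and the attachment point shown in the group's name, and no measurement here accounts for any of these differences.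

The 1H-indol-5-yl group would separate those two changes, showing whether the attachment point or the ring atoms matter more. As far as these compounds go, every group here has two aromatic rings, so it also remains open how a single phenyl ring carrying an amine or a carboxylic acid would behave on this nitrogen.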